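Notes on the step from compound 1 to compound 3

The compounds below may be only part of what the source reports. "The series", "measured", "known", "first", "only" and "open" are said of these compounds alone.

In a functional assay on MGC-803 cells (Homo sapiens) for cytotoxicity, read by MTT assay, with a stated time of 72 h (on this read-out lower numbers stand for stronger inhibition and higher numbers for weaker inhibition), compound 1 `COc1cccc(C=C2C(=O)N(c3ccc(Cl)cc3)N(c3ccc(Cl)cc3)C2=O)c1O` gives 24300 nM and compound 2 `CC(=C1C(=O)N(c2ccc(Cl)cc2)N(c2ccc(Cl)cc2)C1=O)c1ccc(O)cc1` gives 42800 nM and these two values lie within the scatter of each other. Compound 3 `O=C1C(=Cc2ccc(F)cc2F)C(=O)N(c2ccc(Cl)cc2)N1c1ccc(Cl)cc1` has not yet been measured and carries 2,4-difluorophenyl in place of 2-hydroxy-3-methoxyphenyl on a double-bonded chain carbon bound to a double-bonded ring carbon. Among the measured compounds shown here, no measured pair shows this change, and no step beyond the scatter is expected in this assay in either direction. The expected change is a 1.1-fold lower number from compound 1 to compound 3 (0.04 log units; within the scatter) and stays within the scatter. Compound 3 is estimated at 22000 nM within an expected range of 8000 nM to 60000 nM on this read-out.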

Compound 3, half-maximal inhibitory concentration: 35700 nM
Estimate against measurement, compound 3: 1.6-fold (0.21 log units) below; low and high end bracket the measured number.
By their numbers in this assay, from the lowest: compounds 1, 3 and 2 (each within the scatter of the next).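

In this assay, 2,4-difluorophenyl in place of 2-hydroxy-3-methoxyphenyl gives a 1.5-fold higher number from compound 1 to compound 3 (0.17 log units; within the scatter). Among the compounds shown here, this is the first step read at this position: the 2-hydroxy-3-methoxyphenyl group, with its hydrogen-bond donor and acceptors, can be exchanged for a group with none without a step beyond the scatter. No measurement bears on the reason for this result. From the compounds shown here alone, whether an amine or a carboxylic acid in this place would also stay within the scatter of compound 1 remains open.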